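Aryl amide variation in the octadecyl threonine amide series

The source may hold more compounds than are shown below. What is called first, only, known or untested is meant among the compounds shown, and "the series" means these compounds.

The series keeps the octadecyl amide of the threonine core and changes only the aryl group on the carbonyl carbon of the second amide. In a functional assay on SW-620 cells (Homo sapiens) for cytotoxicity, read by MTT assay, with a stated time of 48 h (on this read-out lower numbers stand for stronger inhibition and higher numbers for weaker inhibition), compound 1 `CCCCCCCCCCCCCCCCCCNC(=O)[C@@H](NC(=O)c1ccccc1)[C@@H](C)O` gives 200000 nM. For compound 2 `CCCCCCCCCCCCCCCCCCNC(=O)[C@@H](NC(=O)c1ccco1)[C@@H](C)O` this assay reports only a limit, > 200000 nM. Compound 3 `CCCCCCCCCCCCCCCCCCNC(=O)[C@@H](NC(=O)c1nccc2ccccc12)[C@@H](C)O` gives 136000 nM in this assay, the lowest of the two numbers shown, though a 1.5-fold lower number from compound 1 to compound 3 (0.17 log units; within the scatter) lies within the scatter, and an at least 1.4-fold lower number from compound 2 to compound 3 (0.16 log units; that floor lies within the scatter) rests on a limit (the limit of > 200000 nM in this assay, at which 1 of the 3 values shown sits). Compound 4 `CCCCCCCCCCCCCCCCCCNC(=O)[C@@H](NC(=O)c1cc2ccccc2n1C)[C@@H](C)O` carries 1-methyl-1H-indol-2-yl in place of isoquinolin-1-yl on a carbonyl carbon. Within the data shown here, the steps that bear on it, a number no lower from compound 1 to compound 2 (the limit leaves the size open) and a 1.5-fold lower number from compound 1 to compound 3 (0.17 log units; within the scatter), show that swapping one aryl group for another of similar size has so far moved this assay by no more than the scatter, so no step beyond the scatter is expected in either direction for compound 4. Compound 4 is therefore estimated at 150000 nM in this assay, with a range from 70000 nM to 300000 nM, which means an expected step of a 1.1-fold higher number from compound 3 to compound 4 (0.04 log units; within the scatter).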

Compound 4, half-maximal inhibitory concentration: 124000 nM
Compound 4: the middle estimate sits 1.2-fold (0.08 log units) above what was measured; the measured number falls inside the stated range.
By their numbers in this assay, from the lowest: compounds 4, 3 and 1 (each within the scatter of the next).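

Exchanging the six-membered aromatic ring with one hetero atom in isoquinolin-1-yl for the five-membered one in 1-methyl-1H-indol-2-yl, at the same heavy-atom count, gives a 1.1-fold lower number from compound 3 to compound 4 (0.04 log units; within the scatter) in this assay so this change on the carbonyl carbon separates nothing. Set against phenyl, the new aryl group gives a 1.6-fold lower number from compound 1 to compound 4 (0.21 log units; within the scatter) and so, like isoquinolin-1-yl, it opens no step beyond the scatter at this position. The comparison with furan-2-yl, an at least 1.6-fold lower number from compound 2 to compound 4 (0.20 log units; that floor lies within the scatter) and thus only a floor, rests on a limit: the limit of > 200000 nM in this assay, at which 1 of the 4 values shown sits.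

The aryl groups shown do not tell whether this position can move the read-out beyond the scatter at all. From the compounds shown here alone, whether an aryl group carrying an amine or a carboxylic acid, or a shorter chain in place of octadecyl, would do so stays open.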